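The compounds below may be only part of what the source reports. "The series", "measured", "known", "first", "only" and "open" are said of these compounds alone.

In an ADME assay on L6 cells (Rattus norvegicus) for cytotoxicity (on this read-out lower numbers stand for stronger inhibition and higher numbers for weaker inhibition), three esters on one shared core have been measured so far. Compound 1 `CCN(CC)CC(=O)OC1CC2(N(C)C)CC(c3ccccc3)C1C(c1ccccc1)C2` gives 30100 nM, and compound 2 `CN(C)C12CC(OC(=O)CN3CCCCC3)C(C(c3ccccc3)C1)C(c1ccccc1)C2` gives 29300 nM. Compound 3 `CCN(CC)CCC(=O)OC1CC2(N(C)C)CC(c3ccccc3)C1C(c1ccccc1)C2` gives 23600 nM, which leaves it level with the other two, as its gaps to both lie within the scatter.

Compound 4 `CN(C)C12CC(OC(=O)CCN3CCCCC3)C(C(c3ccccc3)C1)C(c1ccccc1)C2` has not yet been measured. Its structure departs from that of compound 3 in a single place, piperidin-1-yl in place of diethylamino on a saturated chain carbon, two bonds along the chain from a carbonyl carbon: piperidin-1-yl stands in place of diethylamino on a saturated chain carbon, two bonds along the chain from a carbonyl carbon.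

Within the data shown here, the closest precedent is the same exchange made directly on the saturated chain carbon bound to a carbonyl carbon, which gave a 1.0-fold lower number from compound 1 to compound 2 (0.01 log units; within the scatter). The two steps that bring in (diethylamino)methyl were just as small, at a 1.3-fold lower number from compound 1 to compound 3 (0.11 log units; within the scatter) and a 1.2-fold lower number from compound 2 to compound 3 (0.09 log units; within the scatter). None of the three leaves the scatter, so no step beyond the scatter is expected in this assay, and no direction can be favoured. The expected change is a 1.0-fold lower number from compound 3 to compound 4 (0.01 log units; within the scatter), an estimate that stays within the scatter. For compound 4 the estimated value is 23000 nM, with an expected range of 12000 nM to 44000 nM.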

Compound 4, half-maximal inhibitory concentration: 25800 nM
Estimate against measurement, compound 4: 1.1-fold (0.05 log units) below; measured number inside the range.
By their numbers in this assay, from the lowest: compounds 3, 4, 2 and 1 (each within the scatter of the next).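

In this assay, piperidin-1-yl in place of diethylamino on a saturated chain carbon, two bonds along the chain from a carbonyl carbon, gave a 1.1-fold higher number from compound 3 to compound 4 (0.04 log units; within the scatter), so this position tolerates the ring as the saturated chain carbon bound to a carbonyl carbon did. Among these compounds, the chain change now also has a piperidine reading, with (piperidin-1-yl)methyl in place of piperidin-1-yl giving a 1.1-fold lower number from compound 2 to compound 4 (0.06 log units; within the scatter) and (piperidin-1-yl)methyl in place of diethylamino giving a 1.2-fold lower number from compound 1 to compound 4 (0.07 log units; within the scatter), which completes a set of four esters in which no step leaves the scatter. The exchange of diethylamino for piperidin-1-yl therefore reads alike at both places in this assay: the same change on two cores in this assay, a 1.0-fold lower number (0.01 log units; within the scatter) from compound 1 to compound 2 and a 1.1-fold higher number (0.04 log units; within the scatter) from compound 3 to compound 4, 1.1-fold (0.05 log units) apart, within the scatter of two such steps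

What these four compounds leave open is whether any change to the amine or the chain can move this read-out at all, for instance a morpholin-4-yl group, a smaller amine such as dimethylamino, or a longer chain between the carbonyl and the amine. On these data alone, it also stays open whether the same flat picture would hold with an amide in place of the ester on the shared core.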